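The source may hold more compounds than are shown below. What is called first, only, known or untested is meant among the compounds shown, and "the series" means these compounds.

Measured compounds in a functional assay on HT-1080 cells (Homo sapiens) for cytotoxicity, read by MTT assay, with a stated time of 72 h; on this read-out higher numbers stand for weaker inhibition and lower numbers for stronger inhibition:

Compound 1, `Cn1nc(-c2ccccc2)c2cc(C(=N)Nc3ccccc3)ncc21`, gives 17400 nM
Compound 2, `COc1ccc(Cn2nc(-c3ccccc3)c3cc(C(=N)Nc4ccccc4)ncc32)cc1`, gives 4700 nM
Compound 3, `Cn1ncc2cc(C(=N)Nc3cccc(C(F)(F)F)c3)ncc21`, gives 33800 nM

Compound 1 and compound 2 differ in one place only, (4-methoxyphenyl in place of hydrogen on a saturated chain carbon bound to an aromatic nitrogen), and this change gave a 3.7-fold lower number from compound 1 to compound 2 (0.57 log units; beyond the scatter). Compound 3 shares the same kind of core but is not the same compound as compound 1; the difference between the two cores is not broken down here. Compound 4, `COc1ccc(Cn2ncc3cc(C(=N)Nc4cccc(C(F)(F)F)c4)ncc32)cc1`, has not yet been measured in this assay. It differs from compound 3 by the same change, (4-methoxyphenyl in place of hydrogen on a saturated chain carbon bound to an aromatic nitrogen), at the same place. Since compound 1 to compound 2 gave a 3.7-fold lower number from compound 1 to compound 2 (0.57 log units; beyond the scatter), a step of similar size is expected from compound 3 to compound 4, namely a 3.7-fold lower number from compound 3 to compound 4 (0.57 log units; beyond the scatter). On this basis compound 4 is estimated at 9100 nM, with a likely range from 4000 nM to 25000 nM.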

Compound 4, half-maximal inhibitory concentration: 24900 nM
For compound 4 the middle estimate is 2.7-fold (0.44 log units) below the measured one, within the range that was stated.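

In this assay, replacing methyl with 4-methoxybenzyl gave a 1.4-fold lower number from compound 3 to compound 4 (0.13 log units; within the scatter), so on this core the change had no clear effect. Within the data shown here, the size of the step therefore did not carry over from one core to the other: the same change on two cores in this assay, a 3.7-fold lower number (0.57 log units; beyond the scatter) from compound 1 to compound 2 and a 1.4-fold lower number (0.13 log units; within the scatter) from compound 3 to compound 4, 2.7-fold (0.44 log units) apart, beyond the scatter of two such steps With only two pairs, this does not show which difference between the cores accounts for the gap, or how the change would behave on a third core.

The compounds shown leave open how a plain benzyl group would compare with 4-methoxybenzyl at this place. They also leave open what a longer chain ending in an amine or a carboxylic acid would do there.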